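Notes on replacing fluoro in compound 3

The source may hold more compounds than are shown below. What is called first, only, known or untested is meant among the compounds shown, and "the series" means these compounds.

Measured in a functional assay on Bel-7402 cells (Homo sapiens) for inhibition, read by MTT assay, with a stated time of 24 h, tested at 100 ug/mL (a higher number here means more inhibition of growth at the concentration tested, a lower number less inhibition of growth), so far
compound 1 `O=C(CCCCC1CCSS1)Nc1ccc(OC(F)(F)F)cc1` gives 78.4%
compound 2 `O=C(CCCCC(S)CCS)Nc1ccc(Cl)cc1` gives 25.5%
compound 3 `O=C(CCCCC(S)CCS)Nc1ccc(F)cc1` gives 11.7%

Compound 3 has the lowest of the three numbers. Compound 4 `O=C(CCCCC(S)CCS)Nc1ccc(OC(F)(F)F)cc1` keeps the core of compound 3 and differs by one change trifluoromethoxy in place of fluoro on an aromatic carbon on the aromatic ring. For the measured compounds named here, the only measured step at this place is a number 13.8 percentage points lower from compound 2 to compound 3 (beyond the scatter) and it covers chloro and fluoro only. Compound 1 also holds trifluoromethoxy, but on a different core, so compound 1 at 78.4% suggests an upward direction and gives only a loose guide to size. A modest rise beyond the scatter is therefore expected, and the estimated step is a number 18.3 percentage points higher from compound 3 to compound 4 (beyond the scatter) in this series. Compound 4 is estimated at 30% with an expected range of 15% to 55% as a working figure.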

Compound 4, percent growth inhibition at one concentration: 49.7%
Compound 4: middle estimate off by 19.7 percentage points, on the low side; the measured number falls inside the stated range.
By their numbers in this assay, from the lowest: compound 3; then compound 2; then compound 4; then compound 1.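

In this assay, trifluoromethoxy on the aromatic carbon goes well past both halogens, with a number 38 percentage points higher from compound 3 to compound 4 (beyond the scatter) and a number 24.2 percentage points higher from compound 2 to compound 4 (beyond the scatter), so this place on the ring is not confined to the narrow range seen with chloro and fluoro. The core still counts with trifluoromethoxy held constant: the ringless chain end gives a number 28.7 percentage points lower from compound 1 to compound 4 (beyond the scatter).

Going by these compounds, whether methoxy or trifluoromethyl at this place would match trifluoromethoxy remains open, as does the effect of chloro or fluoro on the core of compound 1. Nothing available bears on the reason for these steps.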